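A few compounds are considered here, and "the series" means these few. Any claim that something is new, unique, unknown or untested is made for them only; others in the source may bear on it.

Measured in a functional assay on NCI-H460 cells (Homo sapiens) for inhibition, read by MTT assay, with a stated time of 72 h; on this read-out higher numbers stand for weaker inhibition and lower numbers for stronger inhibition:
- Compound 1 `COc1cc(NC(C)CCCNC(=O)NNC(=O)Nc2ccc(Cl)cc2)c2ncccc2c1`: 63000 nM
- Compound 2 `COc1cc(NC(C)CCCNC(=O)NNC(=O)Nc2ccc(C(F)(F)F)cc2)c2ncccc2c1`: 12000 nM
- Compound 3 `COc1cc(NC(C)CCCNC(=O)NNC(=O)Nc2ccc(Br)cc2)c2ncccc2c1`: 27000 nM

Compound 3 holds the middle place among these three numbers. The steps around it are a 2.3-fold lower number from compound 1 to compound 3 (0.37 log units; beyond the scatter) and a 2.3-fold higher number from compound 2 to compound 3 (0.35 log units; beyond the scatter).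

In compound 4 `COc1cc(NC(C)CCCNC(=O)Nc2cccc(C(F)(F)F)c2)c2ncccc2c1`, 3-(trifluoromethyl)phenyl stands in place of ((4-bromophenyl)carbamoyl)amino on an amide-type nitrogen (3-(trifluoromethyl)phenyl in place of ((4-bromophenyl)carbamoyl)amino on an amide-type nitrogen). The measured steps only exchange one group on an aromatic carbon, the largest being a 5.3-fold lower number from compound 1 to compound 2 (0.72 log units; beyond the scatter). None of them shows a change of this kind, so they bear on it only loosely. In this assay, as far as these compounds go, no step beyond the scatter is firmly expected, and the direction remains open. The step expected is a 1.4-fold lower number from compound 3 to compound 4 (0.13 log units; within the scatter). The estimate for compound 4 is 20000 nM, with an expected range of 6000 nM to 70000 nM.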

Compound 4, half-maximal inhibitory concentration: 21000 nM
Beside the measured number, compound 4's estimate is 1.1-fold (0.02 log units) below it; the measured number falls inside the stated range.
By their numbers in this assay, from the lowest: compounds 2, 4 and 3 (each within the scatter of the next, the first and the last beyond it); then compound 1.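

In this assay, going by these compounds alone, the first exchange on the amide-type nitrogen, 3-(trifluoromethyl)phenyl in place of ((4-bromophenyl)carbamoyl)amino, gives a 1.3-fold lower number from compound 3 to compound 4 (0.11 log units; within the scatter), so this larger exchange stays within the scatter. The corresponding exchange of ((4-chlorophenyl)carbamoyl)amino gives a 3.0-fold lower number from compound 1 to compound 4 (0.48 log units; beyond the scatter), so what the exchange shows depends on the halogen in the group that leaves. Nothing measured here accounts for either step. As far as these compounds go, how a carboxylic acid or a primary amine on this nitrogen would read in this assay remains open.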